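The compounds below may be only part of what the source reports. "The series", "measured", "known", "first", "only" and "open" are said of these compounds alone.

Compound 2 `Oc1ccccc1/C=N/c1nnc(SCc2nnc(-c3ccccc3Br)o2)s1` gives 7150 nM in a functional assay on A549 cells (Homo sapiens) for inhibition, read by CCK-8 assay (a lower number here means a stronger inhibitor, a higher number a weaker inhibitor), the lowest of the two numbers at hand; compound 1 `Oc1ccccc1/C=N/c1nnc(SCc2nnc(-c3ccccc3Cl)o2)s1` gives 18100 nM. Compound 3 `Cc1ccccc1-c1nnc(CSc2nnc(/N=C/c3ccccc3O)s2)o1` differs from compound 2 by methyl in place of bromo on an aromatic carbon. Among the compounds with values here, the only measured step, a 2.5-fold lower number from compound 1 to compound 2 (0.40 log units; beyond the scatter), exchanged chloro for bromo rather than bromo for methyl, so it bears only loosely on this change. With no closer guide, a modest rise in the number is expected, a 1.7-fold higher number from compound 2 to compound 3 (0.22 log units; within the scatter), because the step of a 2.5-fold lower number from compound 1 to compound 2 (0.40 log units; beyond the scatter) shows that swapping this group moves the number beyond the scatter. Compound 3 is therefore estimated at 12000 nM, with a range from 4000 nM to 36000 nM.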

Compound 3, half-maximal inhibitory concentration: 7850 nM
Estimate against measurement, compound 3: 1.5-fold (0.18 log units) above, within the range that was stated.
By their numbers in this assay, from the lowest: compounds 2 and 3 (each within the scatter of the next); then compound 1.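

In this assay, methyl serves as well as bromo at this place on the ring, with a 1.1-fold higher number from compound 2 to compound 3 (0.04 log units; within the scatter), so a group need not be a halogen to keep the number this low. Chloro is the group that stands apart among these three, and a 2.3-fold lower number from compound 1 to compound 3 (0.36 log units; beyond the scatter). Nothing at hand explains why methyl and bromo give matching numbers while chloro does not.

On these data alone, whether an amine, a carboxylic acid or a methoxy group in the same place would hold the number or shift it remains open.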